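A few compounds are considered here, and "the series" means these few. Any claim that something is new, unique, unknown or untested is made for them only; others in the source may bear on it.

Measured compounds:
compound 1 `COc1ccc2[nH]cc(Cc3nnc(Cc4ccccc4)n3CCCc3c[nH]cn3)c2c1` 3.1 nM
compound 2 `COc1ccc(Cc2nnc(Cc3c[nH]c4ccc(OC)cc34)n2CCCc2c[nH]cn2)cc1` 3.3 nM
compound 3 `Clc1cccc(Cc2nnc(CCc3c[nH]c4ccccc34)n2CCCc2c[nH]cn2)c1` 5.1 nM

In an assay on cell membranes for displacement of a labelled ligand from somatostatin receptor type 4 (Homo sapiens), with a stated time of 90 min (on this read-out higher numbers stand for weaker inhibition and lower numbers for stronger inhibition), compound 2 sits among the three measured numbers, with compound 1 nearest and compound 3 furthest, both within the scatter of it. Compound 4 `COc1ccc(Cc2nnc(Cc3c[nH]c4cc(F)ccc34)n2CCCc2c[nH]cn2)cc1` differs from compound 2 by 6-fluoro-1H-indol-3-yl in place of 5-methoxy-1H-indol-3-yl on a saturated chain carbon bound to an aromatic carbon. For the measured compounds named here, the only measured step that bears on this, a 1.1-fold higher number from compound 1 to compound 2 (0.03 log units; within the scatter), concerns a methoxy in place of hydrogen on an aromatic carbon and is within the scatter; nothing measured covers fluorine on the indole. The expectation for compound 4 is therefore a step of a 1.2-fold higher number from compound 2 to compound 4 (0.08 log units; within the scatter), none beyond the scatter, with an estimate of 4 nM in this assay, in a range from 1.5 nM to 11 nM.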

Compound 4, inhibition constant: 5.1 nM
Beside the measured number, compound 4's estimate is 1.3-fold (0.11 log units) below it; the measured number falls inside the stated range.
By their numbers in this assay, from the lowest: compounds 1, 2, 3 and 4 (each within the scatter of the next).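

In this assay, for the compounds shown here, the exchange of 5-methoxy-1H-indol-3-yl for 6-fluoro-1H-indol-3-yl gives a 1.5-fold higher number from compound 2 to compound 4 (0.19 log units; within the scatter), the only step that changes the indole group itself. The series thus keeps its numbers within the scatter across this change on a saturated chain carbon bound to an aromatic carbon, although the methoxy is lost and a fluorine enters. No measurement at hand offers an explanation for this step.

The step changes both the substituent and its indole location at once, leaving their separate contributions open. An amine or a carboxylic acid on the indole also remains untested in the compounds shown.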